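The compounds below may be only part of what the source reports. "The series", "measured", "known", "first", "only" and "open" are said of these compounds alone.

Compound 1 `CCc1ccc(-c2nn3cc(-c4cccc(N)c4)nc3s2)cc1` gives 22000 nM in a functional assay on CCRF-CEM cells (Homo sapiens) for inhibition, read by cell counting, with a stated time of 3 days; a lower number here means a stronger inhibitor, a higher number a weaker inhibitor.
Compound 2 `COc1ccc(-c2nn3cc(-c4cccc(N)c4)nc3s2)cc1` gives >= 250000 nM in this assay; this is a limit of the assay, not a number.
Compound 3 `Nc1cccc(-c2cn3nc(-c4ccccc4)sc3n2)c1` gives 33000 nM in this assay.

All three share one core and differ only in the group on the phenyl ring that hangs from it. Among the two compounds with a number, compound 3 has the higher one, but its gap to compound 1 is small: a 1.5-fold higher number from compound 1 to compound 3 (0.18 log units; within the scatter). The third value is a limit and cannot be ranked.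

Compound 4 `Nc1cccc(-c2cn3nc(-c4ccc(F)cc4)sc3n2)c1` differs from compound 3 in one place: fluoro in place of hydrogen on an aromatic carbon. Among the compounds with values here, no measured step introduces fluoro, so the expectation has to lean on what the same position tolerates. Replacing ethyl with methoxy there gave an at least 11-fold higher number from compound 1 to compound 2 (1.05 log units; beyond the scatter), and removing methoxy gave an at least 7.5-fold lower number from compound 2 to compound 3 (0.87 log units; beyond the scatter), whereas removing ethyl gave a 1.5-fold higher number from compound 1 to compound 3 (0.18 log units; within the scatter). The position is thus not indifferent to what sits on it, yet a small group need not cost anything, as compound 1 shows. Fluoro brings one heavy atom and no donor or acceptor, so the expected step in this assay is a 1.1-fold lower number from compound 3 to compound 4 (0.04 log units; within the scatter), within the scatter. The estimated value for compound 4 is 30000 nM, with a range from 10000 nM to 100000 nM.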

Compound 4, half-maximal inhibitory concentration: >= 250000 nM
Compound 4 gave a limit, no number (the forecaster's own chance of this, stated with the estimate: 15%); at least 8.3-fold (0.92 log units) between middle value and limit.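

The earlier compounds shown here made this position look forgiving of small changes, with ethyl and hydrogen lying within the scatter of each other, but in this assay a single fluorine on that carbon is enough to give an at least 7.5-fold higher number from compound 3 to compound 4 (0.87 log units; beyond the scatter). The ethyl compound fares no better against it, with an at least 11-fold higher number from compound 1 to compound 4 (1.05 log units; beyond the scatter), so the size of the group does not sort these compounds: ethyl keeps a number, while the methoxy of compound 2 and the fluoro of compound 4, the two compounds that go against any rule based on size, do not. The value of compound 4 is a limit, as is that of compound 2, so the true size of the loss stays hidden and the step between these two compounds cannot be read: the limit of >= 250000 nM in this assay, at which 2 of the 4 values shown sit.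

As far as these compounds go, what separates ethyl from fluoro and methoxy here remains open, and a chloro, a methyl or an amine on the same carbon would show whether hydrogen and ethyl are the exceptions. The compounds shown also leave open whether fluoro costs as much elsewhere on this ring.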